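Swapping Allyl for Isopropyl on the Ring Amine

This account rests on a few compounds, and the source may have more. Where it says the series, first, only, none or still open, it means among the compounds named here.

Compound 1 `C=CCNc1nnc(SCC(=O)N(Cc2cccc([N+](=O)[O-])c2)c2ccc(F)cc2)s1` was tested in an assay on isolated protein for inhibition of Amine oxidase [flavin-containing] B (Homo sapiens), read by fluorescence and Amplex Red, with a stated time of 30 min, tested at 1 mM (on this read-out higher numbers stand for a stronger effect at the one concentration tested and lower numbers for a weaker effect), where compound 1 gives 38.1%. Of the two numbers in hand this one sits at the low end, yet the gap to the other compound is within the scatter, so the two cannot be told apart. Going by the values given here, the other compound is compound 2 `CCCNc1nnc(SCC(=O)N(Cc2cccc([N+](=O)[O-])c2)c2ccc(F)cc2)s1`, which in this assay gives 42.7%; the step of a number 4.6 percentage points higher from compound 1 to compound 2 (within the scatter) is the only measured step and concerns the chain on the nitrogen on an aromatic ring. Not yet measured is compound 3 `CC(C)Nc1nnc(SCC(=O)N(Cc2cccc([N+](=O)[O-])c2)c2ccc(F)cc2)s1`, which differs from compound 1 in one place: isopropyl in place of allyl on a nitrogen on an aromatic ring. The step from compound 1 to compound 2 bears on this change, since it also exchanges one short chain for another at the same nitrogen, and it stayed within the scatter. The expected step of a number 1.9 percentage points higher from compound 1 to compound 3 (within the scatter) for compound 3 is therefore one within the scatter, in no particular direction. Compound 3 is thus estimated to give 40%, with a range from 28% to 52%.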

Compound 3, a percentage reported as inhibition, at one concentration (the size of the read-out at that concentration, not a potency): 36%
Compound 3: middle estimate off by 4 percentage points, on the high side, and the stated range covers the measured number.
By their numbers in this assay, from the lowest: compounds 3, 1 and 2 (each within the scatter of the next).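

In this assay, isopropyl in place of allyl gives a number 2.1 percentage points lower from compound 1 to compound 3 (within the scatter), and isopropyl in place of propyl gives a number 6.7 percentage points lower from compound 2 to compound 3 (within the scatter). On this nitrogen, then, allyl, propyl and isopropyl cannot be told apart on this read-out, and removing the double bond of allyl while also changing the chain to isopropyl produces no step beyond the scatter. Nothing further is available that would explain this result.

Going by these compounds, what a longer chain such as hexyl, a ring such as cyclohexyl or a plain unsubstituted amino group would give at this position stays open. Also open, on these data alone, is whether these three compounds would still be indistinguishable as true potencies, since a reading at one concentration gives only the size of the effect there.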